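Aryl Sulfonamide Series: Changing the Aryl on Sulfur

The source may hold more compounds than are shown below. What is called first, only, known or untested is meant among the compounds shown, and "the series" means these compounds.

In a functional assay (Cavia porcellus) for antagonist activity at thromboxane A2 receptor (Homo sapiens) (on this read-out higher numbers stand for weaker binding and lower numbers for tighter binding), compound 1 `CC(C)C(=O)N1C[C@@H](C/C=C\CCC(=O)O)[C@@H](c2ccccc2O)C1` gives 200 nM, compound 2 `O=C(O)CC/C=C\C[C@@H]1CN(Cc2ccccc2)C[C@@H]1c1ccccc1O` gives 251 nM and compound 3 `O=C(O)CC/C=C\C[C@@H]1CN(S(=O)(=O)c2ccc(Cl)cc2)C[C@@H]1c1ccccc1O` gives 1 nM. The step of a 1.3-fold higher number from compound 1 to compound 2 (0.10 log units; within the scatter) leaves those two within the scatter of each other, whereas a 200-fold lower number from compound 1 to compound 3 (2.30 log units; beyond the scatter) and a 250-fold lower number from compound 2 to compound 3 (2.40 log units; beyond the scatter) are large. Compound 3 therefore stands lowest of the three numbers in this assay, with compound 1 nearest and compound 2 furthest.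

Compound 4 `O=C(O)CC/C=C\C[C@@H]1CN(S(=O)(=O)c2cccc3cnccc23)C[C@@H]1c1ccccc1O` keeps the sulfonamide of compound 3 and differs only on the sulfonyl sulfur: isoquinolin-5-yl in place of 4-chlorophenyl on a sulfonyl sulfur. None of the three measured steps changes this aryl group; each exchanges the whole substituent on the ring nitrogen, so they show only that the sulfonyl is what separates compound 3 from compounds 1 and 2, and none tests the aryl itself. The expectation for compound 4 in this assay is thus a number close to that of compound 3, with the step of a 2.0-fold higher number from compound 3 to compound 4 (0.30 log units; within the scatter) expected to stay within the scatter. The estimate for compound 4 is 2 nM, with a range from 0.4 nM to 12 nM to allow for the untested change.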

Compound 4, dissociation constant: 0.316 nM
The estimate for compound 4 lay 6.3-fold (0.80 log units) above the measured number; the whole stated range lies above it.
By their numbers in this assay, from the lowest: compound 4; then compound 3; then compounds 1 and 2 (each within the scatter of the next).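

Among the compounds shown here, the aryl on the sulfonyl sulfur is tested directly here for the first time: in this assay isoquinolin-5-yl in place of 4-chlorophenyl gives a 3.2-fold lower number from compound 3 to compound 4 (0.50 log units; beyond the scatter) as a modest step. This position therefore accepts the larger aryl with its added ring and hetero atom without loss, although this rests on one pair and the step is much smaller than those to compound 3 from compounds 1 and 2. Nothing at hand explains the shift or assigns it to the added ring or to the hetero atom.

From the compounds shown here alone, whether the lower number needs the ring nitrogen of isoquinolin-5-yl or only the second aromatic ring remains open, and a naphthyl group on the sulfur would separate the two. Also open, going by these compounds, is how an unsubstituted phenyl group would compare at this position.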